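From dimethylamino to methyl on a thiophen-3-yl compound

A few compounds are considered here, and "the series" means these few. Any claim that something is new, unique, unknown or untested is made for them only; others in the source may bear on it.

Measured in an ADME assay on BJ cells (Homo sapiens), read by MTT assay, with a stated time of 72 h; on this read-out lower numbers stand for stronger inhibition and higher numbers for weaker inhibition:
- compound 1 `CN(C)c1ncnc2c1c(-c1ccsc1)cn2[C@@H]1O[C@H](CO)[C@@H](O)[C@H]1O`: > 100000 nM (a limit)
- compound 2 `CN(C)c1ncnc2c1c(-c1cc3ccccc3o1)cn2[C@@H]1O[C@H](CO)[C@@H](O)[C@H]1O`: > 100000 nM (a limit)
- compound 3 `C#Cc1cn([C@@H]2O[C@H](CO)[C@@H](O)[C@H]2O)c2ncnc(N(C)C)c12`: 410 nM

Compound 1 stands at the limit of > 100000 nM in this assay, at which 2 of the 3 values shown sit. For compound 1 this is a limit and not a number. Compound 4 `Cc1ncnc2c1c(-c1ccsc1)cn2[C@@H]1O[C@H](CO)[C@@H](O)[C@H]1O` keeps the thiophen-3-yl group and differs elsewhere: methyl in place of dimethylamino on an aromatic carbon. Among the compounds with values here, no measured step changes that place. The nearest evidence lies at the thiophen-3-yl group: a step that the two limits leave unreadable from compound 1 to compound 2, and an at least 240-fold lower number from compound 1 to compound 3 (2.38 log units; beyond the scatter). Within the data shown here, compound 3 shows only that the shared core can give a number clear of the limit. A lower number is therefore expected in this assay, of uncertain size, and a result at the limit remains possible. The expected step is an at least 6.6-fold lower number from compound 1 to compound 4 (0.82 log units; beyond the scatter). Compound 4 is estimated at 15000 nM, with an expected range from 1000 nM to 100000 nM.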

Compound 4, half-maximal inhibitory concentration: 96900 nM
Estimate against measurement, compound 4: 6.5-fold (0.81 log units) below; the range from low to high includes it.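

With methyl in place of dimethylamino, compound 4 is the only thiophen-3-yl compound shown that gives a number in this assay, at 96900 nM in this position's first readable result. The change gives an at least 1.0-fold lower number from compound 1 to compound 4 (0.01 log units; that floor lies within the scatter), so no real shift can be claimed from this floor. Compound 1 remains a limit and not a number: the limit of > 100000 nM in this assay, at which 2 of the 4 values shown sit.

On these data alone, how far the true value of compound 1 lies from that of compound 4 stays open. So does the effect on the number of a primary amine or an ethyl chain on this aromatic carbon.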